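Swapping the group on the carbonyl for a heteroaromatic ring

This account rests on a few compounds, and the source may have more. Where it says the series, first, only, none or still open, it means among the compounds named here.

In a functional assay on isolated protein for inhibition of Glucose-dependent insulinotropic receptor (Rattus norvegicus), read by HTRF and cAMP accumulation (on this read-out higher numbers stand for larger maximal responses and lower numbers for smaller maximal responses), the three measured compounds gave:
Compound 1 `Cc1nc(S(C)(=O)=O)ccc1Oc1ncnc(OC2CCN(C(=O)OC(C)C)CC2)c1F`: 77%
Compound 2 `Cc1nc(S(C)(=O)=O)ccc1Oc1ncnc(OC2CCN(C(=O)OC3(C(F)(F)F)COC3)CC2)c1F`: 84%
Compound 3 `Cc1nc(S(C)(=O)=O)ccc1Oc1ncnc(OC2CCN(C(=O)C(C)(C)F)CC2)c1F`: 74%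

Compound 3 carries the smallest of the three numbers, yet its gaps to the others, a number 3 percentage points lower from compound 1 to compound 3 (within the scatter) and a number 10 percentage points lower from compound 2 to compound 3 (within the scatter), both lie within the usual scatter, so the three compounds cannot be told apart on this read-out. Compound 4 `Cc1nc(S(C)(=O)=O)ccc1Oc1ncnc(OC2CCN(C(=O)c3nc(C(C)(C)F)no3)CC2)c1F` is the next step from compound 3, and the change sits on the same carbonyl carbon: a group of 9 heavy atoms (5 carbon, 2 nitrogen, 1 oxygen, 1 fluorine; one five-membered aromatic ring with 3 hetero atoms) in place of a group of 4 heavy atoms (3 carbon, 1 fluorine; no ring), on a carbonyl carbon. The two earlier changes on that carbonyl carbon, a number 3 percentage points lower from compound 1 to compound 3 (within the scatter) and a number 10 percentage points lower from compound 2 to compound 3 (within the scatter), produced no shift beyond the scatter, so the expected step from compound 3 to compound 4 is a number 4 percentage points higher from compound 3 to compound 4 (within the scatter), meaning none beyond the scatter. Compound 4 is therefore estimated at 78%, within a range from 65% to 90%.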

Compound 4, largest response reached (reported as efficacy), in percent of the reference or control that the assay uses: 84%
The estimate for compound 4 lay 6 percentage points below the measured number; measured number inside the range.
By their numbers in this assay, from the lowest: compounds 3, 1, 2 and 4 (each within the scatter of the next).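

On the carbonyl carbon, the five-membered aromatic ring bearing 1-fluoro-1-methylethyl gives no shift beyond the scatter in this assay: there is a number 10 percentage points higher from compound 3 to compound 4 (within the scatter) and no change at the digits printed from compound 2 to compound 4 (within the scatter) and a number 7 percentage points higher from compound 1 to compound 4 (within the scatter). This position therefore accepts an aromatic ring as well as the open-chain and oxetane-containing groups, and the four compounds still cannot be told apart on this read-out. No evidence at hand speaks to why this is so. From the compounds shown here alone, what a carboxylic acid or an amine on that carbonyl carbon would give remains open. So does the result for a plain phenyl ring there.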